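The source may hold more compounds than are shown below. What is called first, only, known or untested is meant among the compounds shown, and "the series" means these compounds.

Compound 1 `CCCCCNc1nc(Nc2ccc([N+](=O)[O-])cc2)nc(OCC(F)(F)F)n1`: 35%
Compound 2 `CS(=O)(=O)NC(=O)c1ccc(Nc2nc(NC3(c4ccc(Cl)cc4)CC3)nc(OCC(F)(F)F)n2)cc1`: 85%

Among the two compounds measured in an ADME assay on microsomes from liver (Rattus norvegicus) for metabolic stability, with a stated time of 10 min (a higher number here means that more of the compound is left, a lower number that less of the compound is left), compound 2 stands highest; its nearest neighbour, compound 1, lies lower by a gap beyond the usual scatter. Compound 3 `O=C(NS(=O)(=O)CCNCc1ccccc1)c1ccc(Nc2nc(NC3(c4ccc(Cl)cc4)CC3)nc(OCC(F)(F)F)n2)cc1` has not yet been measured. It differs from compound 2 by (benzylamino)methyl in place of hydrogen on a saturated chain carbon bound to a sulfonyl sulfur. Going by the values given here, no measured pair shows this change, so its size is unknown from the data. In this assay the expected step of a number 25 percentage points lower from compound 2 to compound 3 (beyond the scatter) is a drop beyond the scatter. Compound 3 is estimated at 60%, within a range from 35% to 85%.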

Compound 3, percent of the compound remaining: 100%
Estimate against measurement, compound 3: 40 percentage points below; the measured number lies above the stated range.
By their numbers in this assay, from the lowest: compound 1; then compound 2; then compound 3.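

In this assay, (benzylamino)methyl in place of hydrogen on a saturated chain carbon bound to a sulfonyl sulfur gives a number 15 percentage points higher from compound 2 to compound 3 (beyond the scatter). This single pair shows that this place can carry the change from methyl to 2-(benzylamino)ethyl with no loss in the percent of compound remaining. Nothing at hand accounts for the rise. From the compounds shown here alone, it remains open whether the benzyl ring matters, or whether a simple primary amine, a carboxylic acid or a plain longer chain at this place would give a similar number.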